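Replacing propanoyl with 1-hydroxypropyl on the ring

A few compounds are considered here, and "the series" means these few. Any claim that something is new, unique, unknown or untested is made for them only; others in the source may bear on it.

For the measured compounds named here, compound 2 `CCC(=O)C1=CCCCC1S(=O)(=O)Cc1ccc(F)cc1Cl` is the only compound with a numerical result in a functional assay on RAW264.7 cells (Mus musculus), read by fluorescence (a lower number here means a stronger inhibitor, a higher number a weaker inhibitor), where compound 2 gives 64 nM. Compound 1 `CC(=O)OCC1=CCCCC1S(=O)(=O)Cc1ccc(F)cc1Cl` sits at the limit of > 10000 nM in this assay, at which 1 of the 2 values shown sits, so compound 1 gives > 10000 nM, a limit rather than a number. Going by the values given here, the single measured step on the double-bonded ring carbon, an at least 150-fold lower number from compound 1 to compound 2 (2.19 log units; beyond the scatter), was large. Compound 3 `CCC(O)C1=CCCCC1S(=O)(=O)Cc1ccc(F)cc1Cl` carries 1-hydroxypropyl in place of propanoyl on a double-bonded ring carbon. Since this ring carbon responded strongly in an at least 150-fold lower number from compound 1 to compound 2 (2.19 log units; beyond the scatter), a weakening step is expected, a 13-fold higher number from compound 2 to compound 3 (1.10 log units; beyond the scatter). Compound 3 is therefore estimated at 800 nM, with a likely range from 150 nM to 5000 nM.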

Compound 3, half-maximal inhibitory concentration: > 10000 nM
Compound 3 was reported as a limit; the forecaster's own chance of this, stated with the estimate: 25%; at least 12-fold (1.09 log units) between middle value and limit.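

The change brings an at least 150-fold higher number from compound 2 to compound 3 (2.19 log units; beyond the scatter) and shows that this ring carbon does not respond to chain size alone: propanoyl and 1-hydroxypropyl each hold 4 heavy atoms, yet only propanoyl gives a number in this assay here. Compound 3 thus joins compound 1 at a limit, and the step between these two cannot be read: the limit of > 10000 nM in this assay, at which 2 of the 3 values shown sit.

From the compounds shown here alone, whether an amide, a carboxylic acid or a longer chain on this carbon would keep the activity of compound 2 stays open. Going by these compounds, how far compound 1 and compound 3 lie past the limit also stays open.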